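Swapping the Aryl Substituent: Expectation for Compound 3

The source may report more compounds than this note shows. Statements on the series, on what has been measured and on what is new or still open speak of the compounds shown alone.

Measured compounds:
compound 1, `O=C1N=C(N2CCC[C@H]2C(=O)Nc2ccc3ncnc(Nc4cccc(Cl)c4)c3c2)S/C1=C/c1ccccc1F`, gives 18200 nM in a functional assay on HepG2 cells (Homo sapiens) for antiproliferative activity, read by MTT assay; a lower number here means a stronger inhibitor, a higher number a weaker inhibitor
compound 2, `COc1ccccc1/C=C1/SC(N2CCC[C@H]2C(=O)Nc2ccc3ncnc(Nc4cccc(Cl)c4)c3c2)=NC1=O`, gives 22100 nM in this assay

Compound 1 holds the lower of the two numbers, yet its step to compound 2, a 1.2-fold higher number from compound 1 to compound 2 (0.08 log units; within the scatter), lies within the scatter, so the two cannot be ordered. Compound 3, `O=C1N=C(N2CCC[C@H]2C(=O)Nc2ccc3ncnc(Nc4cccc(Cl)c4)c3c2)S/C1=C/c1cccc(Cl)c1`, is not yet measured; it differs from compound 1 by 3-chlorophenyl in place of 2-fluorophenyl on a double-bonded chain carbon bound to a double-bonded ring carbon. Among the measured compounds shown here, no measured step exchanges exactly these two groups; the one known step on the same ring, a 1.2-fold higher number from compound 1 to compound 2 (0.08 log units; within the scatter), stayed within the scatter. Compound 3 is therefore expected to stay close to compound 1, with a 1.0-fold lower number from compound 1 to compound 3 (0.00 log units; within the scatter) not beyond the scatter. The estimate for compound 3 is 18000 nM, within 7000 nM to 45000 nM.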

Compound 3, half-maximal inhibitory concentration: 27600 nM
Compound 3: middle estimate off by 1.5-fold (0.19 log units), on the low side; the range from low to high includes it.
By their numbers in this assay, from the lowest: compounds 1, 2 and 3 (each within the scatter of the next).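

Exchanging 2-fluorophenyl for 3-chlorophenyl gives a 1.5-fold higher number from compound 1 to compound 3 (0.18 log units; within the scatter), and exchanging 2-methoxyphenyl for 3-chlorophenyl gives a 1.2-fold higher number from compound 2 to compound 3 (0.10 log units; within the scatter). Both steps stay within the scatter, so a chlorine-bearing ring with its substituent numbered differently joins the two earlier groups without separating from them in this assay. At this position, all three substituted phenyl groups therefore remain indistinguishable.

From the compounds shown here alone, whether an amine or a carboxylic acid on this ring, or a pyridine ring in its place, would produce a step beyond the scatter remains open. Nothing available explains why these three numbers stay so close.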